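The source may report more compounds than this note shows. Statements on the series, on what has been measured and on what is new or still open speak of the compounds shown alone.

Measured so far:
- compound 1 `Cc1ncnc2c1c(-c1cccs1)cn2[C@@H]1O[C@H](CO)[C@@H](O)[C@H]1O`: > 20000 nM (a limit)
- compound 2 `O=c1[nH]cnc2c1c(-c1cc3ccccc3o1)cn2[C@@H]1O[C@H](CO)[C@@H](O)[C@H]1O`: > 20000 nM (a limit)
- compound 3 `Nc1nc(N)c2c(-c3ccccc3)cn([C@@H]3O[C@H](CO)[C@@H](O)[C@H]3O)c2n1`: > 20000 nM (a limit)

All three readings come from a functional assay on A549 cells (Homo sapiens), read by MTT assay, with a stated time of 72 h; a lower number here means a stronger inhibitor, a higher number a weaker inhibitor. In this assay compound 2 gives > 20000 nM, which is a limit of the assay and not a number. The same holds for compound 1, whose reading > 20000 nM is a limit. Compound 3 likewise returns only the limit > 20000 nM. So compound 2 cannot be placed relative to the other two: every value shown sits at the limit of > 20000 nM in this assay, at which 3 of the 3 values shown sit, and no step between measured compounds is resolved by the numbers.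

The unmeasured compound 4 `O=c1[nH]cnc2c1c(-c1ccccc1)cn2[C@@H]1O[C@H](CO)[C@@H](O)[C@H]1O` differs from compound 2 in one place: phenyl in place of 1-benzofuran-2-yl on an aromatic carbon. Compound 3 already carries the phenyl group at the same ring carbon, on a differently substituted core, and gives only a limit in this assay. Among the measured compounds shown here, with three limits and no resolved step, there is no ground to expect the change to pull compound 4 into the measurable range; the step from compound 2 to compound 4 is expected to be none beyond the scatter, as a step that the limit leaves unreadable from compound 2 to compound 4. Compound 4 is therefore expected to sit at about 40000 nM, within 15000 nM to 200000 nM, most likely reported again as a limit.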

Compound 4, half-maximal inhibitory concentration: > 100000 nM
Compound 4: a limit, no number; the forecaster's own chance of this, stated with the estimate: 85%; middle value at least 2.5-fold (0.39 log units) away from the limit.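

Compound 4 gives > 100000 nM in this assay, which is a limit and not a number. Compound 2 gives > 20000 nM, also a limit, so no step can be read between compound 2 and compound 4. The compounds shown leave open how phenyl and 1-benzofuran-2-yl compare on this core, and whether any compound in the series reaches a measurable value in this assay.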